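Swapping the Anilide Ring While Staying at the Limit

This account rests on a few compounds, and the source may have more. Where it says the series, first, only, none or still open, it means among the compounds named here.

Among the compounds with values here, compound 2 `CCCCCN1C(=O)C/C(=C\c2cccc(C(=O)Nc3cccc(F)c3)c2)C1=O` is one of two compounds measured in an ADME assay on SW480 cells (Homo sapiens) for cytotoxicity, read by MTT assay, with a stated time of 72 h; on this read-out lower numbers stand for stronger inhibition and higher numbers for weaker inhibition. In this assay compound 2 gives > 100000 nM, which is a limit of the assay rather than a number. Compound 1 `Cc1ccc(N2C(=O)C/C(=C\c3cccc(C(=O)Nc4cccc(F)c4)c3)C2=O)cc1` carries a 4-methylphenyl instead of the pentyl on the ring nitrogen, and in this assay compound 1 gives 96900 nM. Within the data shown here, the step of an at least 1.0-fold higher number from compound 1 to compound 2 (0.01 log units; that floor lies within the scatter) is the only measured step, and it changes the group on the ring nitrogen, not the anilide. Of the two values, one sits at the limit of > 100000 nM in this assay, at which 1 of the 2 values shown sits. Compound 3 `CCCCCN1C(=O)C/C(=C\c2cccc(C(=O)Nc3ccc(C)cc3)c2)C1=O` differs from compound 2 by 4-methylphenyl in place of 3-fluorophenyl on an amide-type nitrogen. Among the measured compounds shown here, no measured step alters this anilide position, so nothing shows how far it can move the number. For the measured compounds named here, both compounds measured so far show weak inhibition, and the one measured step lies within the scatter. Compound 3 is therefore expected to differ by only a number no higher from compound 2 to compound 3 (the limit leaves the size open), no more than the scatter. The estimate for compound 3 is 100000 nM, ranging from 50000 nM to 200000 nM.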

Compound 3, half-maximal inhibitory concentration: > 100000 nM
Compound 3 was reported as a limit (the forecaster's own chance of this, stated with the estimate: 60%); the middle value sits exactly at the limit.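

Within the data shown here, no step from compound 2 to compound 3 can be read in this assay: each of these two compounds is reported only as a limit of the assay, not as a number. The compounds shown leave open whether replacing 3-fluorophenyl with 4-methylphenyl on the amide nitrogen changes the read-out at all, and by how much.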